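The source may report more compounds than this note shows. Statements on the series, on what has been measured and on what is new or still open speak of the compounds shown alone.

In a physicochemical assay for lipophilicity, using the shake flask method (on this read-out lower numbers stand for lower lipophilicity and higher numbers for higher lipophilicity), three compounds have been measured so far. Compound 1 `C[C@H](Oc1cc2cc(C#N)ccc2nc1N)c1cc(F)ccc1-n1cccn1` gives 3.8. Compound 2 `C[C@H](Oc1cc2cc(F)ccc2nc1N)c1cc(C(=O)O)ccc1-n1cccn1` gives 0.9, and compound 3 `C[C@H](Oc1cc2cc(F)cc(F)c2nc1N)c1cc(C(=O)O)ccc1-n1cccn1` gives 1. Compound 3 differs from compound 2 by fluoro in place of hydrogen on an aromatic carbon, which gave a number 0.10 log units higher from compound 2 to compound 3 (within the scatter). The difference between the core of compound 1 and that of compound 2 is not broken down here; compound 1 simply stands highest of the three, with compound 3 nearest.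

Compound 4 `C[C@H](Oc1cc2cc(C#N)ccc2nc1N)c1cc(F)c(F)cc1-n1cccn1` is not yet measured. It differs from compound 1 by fluoro in place of hydrogen on an aromatic carbon. Among the compounds with values here, this is the same kind of change as the one from compound 2 to compound 3, but the surroundings differ: in compound 3 the fluoro enters a ring that is part of a fused system, ortho to a fused ring and meta to a fluoro group, whereas in compound 4 it enters ortho to a fluoro group, meta to a 1H-pyrazol-1-yl group and para to a large group. Because a number 0.10 log units higher from compound 2 to compound 3 (within the scatter) was small, compound 4 is expected to move by a number 0.20 log units higher from compound 1 to compound 4 (within the scatter). Compound 4 is therefore estimated at 4, most likely between 3.7 and 4.4.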

Compound 4, distribution coefficient: 4.3
For compound 4 the middle estimate is 0.30 log units below the measured one; the range from low to high includes it.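

In this assay, fluoro in place of hydrogen on an aromatic carbon gave a step beyond the scatter on the core of compound 1 (a number 0.50 log units higher from compound 1 to compound 4 (beyond the scatter)), whereas the same kind of change on another core stayed within the scatter (a number 0.10 log units higher from compound 2 to compound 3 (within the scatter)). This shows that the size of the step need not carry over from one core to another in this series. It does not show what sets the size, since the two pairs differ in both core and the place of the new fluoro, and nothing measured explains the result.

The compounds shown leave open whether a chloro or methoxy group at that same place would move the number as fluoro did. They also leave open whether the larger step would recur in a compound carrying the carboxylic acid of compound 2.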